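The compounds below may be only part of what the source reports. "The series", "measured", "known", "first", "only" and "open" are said of these compounds alone.

Measured compounds:
- compound 1, `C/C=C\C=C\[C@](C)(O)C/C=C/[C@H]1[C@H](O)CC(=O)[C@@H]1CC/C=C\CCC(=O)OC`: 0.306 mg/kg
- compound 2, `COC(=O)CC/C=C\CC[C@H]1C(=O)C[C@@H](O)[C@@H]1/C=C/C[C@@](C)(O)/C=C/C(C)=C(C)C`: no number, only a limit, see below

In a functional assay on the whole organism with Rattus norvegicus as the target (a higher number here means that more compound is needed for the effect, a lower number that less compound is needed), compound 1 gives 0.306 mg/kg. For compound 2 this assay reports only a limit, > 3.16 mg/kg, which is a limit of the assay and not a number (the limit of > 3.16 mg/kg in this assay, at which 1 of the 2 values shown sits). For the measured compounds named here, the one step measured so far, an at least 10-fold higher number from compound 1 to compound 2 (1.01 log units; beyond the scatter), is therefore also known only as a bound.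

Compound 3, `COC(=O)CC/C=C\CC[C@H]1C(=O)C[C@@H](O)[C@@H]1/C=C/C[C@@](C)(O)/C=C/C1=CCCC1`, has not yet been measured in this assay. It differs from compound 2 as follows: cyclopent-1-en-1-yl in place of 1,2-dimethylprop-1-en-1-yl on a double-bonded chain carbon bound to a double-bonded chain carbon. Going by the values given here, no measured step covers this exchange; the step from compound 1 to compound 2 concerns a different substituent on the same chain carbon and only shows that compound 2 already sits at the limit. With compound 2 known only as a limit, no direction can be read for this assay, and the step is expected to be a step that the limit leaves unreadable from compound 2 to compound 3, within the scatter of that bound.

Compound 3 is accordingly expected to give about 3.5 mg/kg in this assay, with a range from 0.8 mg/kg to 15 mg/kg, and a limit rather than a number is a likely outcome.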

Compound 3, dose for half-maximal effect: > 3.16 mg/kg
Compound 3 was reported as a limit; the forecaster's own chance of this, stated with the estimate: 55%; the middle value does not contradict the limit.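

In this assay, cyclopent-1-en-1-yl in place of prop-1-en-1-yl on a double-bonded chain carbon bound to a double-bonded chain carbon gives an at least 10-fold higher number from compound 1 to compound 3 (1.01 log units; beyond the scatter), and this step is known only as a bound. A group with a five-membered non-aromatic ring of carbon only therefore ends at the same limit as the open-chain 1,2-dimethylprop-1-en-1-yl of compound 2, so among the three compounds shown only the prop-1-en-1-yl of compound 1 gives a number rather than a limit. The exchange between compound 2 and compound 3 cannot be read, because both results are limits and not numbers: the limit of > 3.16 mg/kg in this assay, at which 2 of the 3 values shown sit.

Where the true values of compound 2 and compound 3 lie in this assay stays open, so the two groups cannot be ordered against each other. Also open is how this place responds to groups unlike those shown, such as a plain methyl, a phenyl or a chain ending in an amine, and whether any of them gives a number rather than a limit.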